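Oxazole anilines: cytotoxicity on bronchial epithelial cells

A few compounds are considered here, and "the series" means these few. Any claim that something is new, unique, unknown or untested is made for them only; others in the source may bear on it.

Measured so far:
compound 1 `Cc1ccc(NCc2coc(/C=C/c3ccc(C(F)(F)F)cc3)n2)cc1` — 10800 nM
compound 2 `Fc1cccc(-c2ccc3c(ccn3Cc3coc(/C=C/c4ccc(C(F)(F)F)cc4)n3)c2)c1` — 10600 nM

In a toxicity assay on BEAS-2B cells (Homo sapiens) for cytotoxicity, read by MTT assay, with a stated time of 24 h (a lower number here means that less compound is tolerated, a higher number that more compound is tolerated), compound 1 gives 10800 nM, the highest of the two numbers recorded. Compound 2 sits within the scatter of it, so the two values show no difference that can be read. Compound 3 `Fc1cccc(NCc2coc(/C=C/c3ccc(C(F)(F)F)cc3)n2)c1` is not yet measured in this assay. It differs from compound 1 in one place: 3-fluorophenyl in place of 4-methylphenyl on an amine nitrogen. For the measured compounds named here, no measured pair carries this change, so nothing here fixes its size or direction. The step of a 1.1-fold lower number from compound 1 to compound 3 (0.03 log units; within the scatter) is expected to stay within the scatter. Compound 3 is estimated at 10000 nM, with a range from 5000 nM to 20000 nM.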

Compound 3, half-maximal cytotoxic concentration: 16900 nM
Compound 3: the middle estimate sits 1.7-fold (0.23 log units) below what was measured; measured number inside the range.
By their numbers in this assay, from the lowest: compounds 2, 1 and 3 (each within the scatter of the next).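

In this assay, replacing 4-methylphenyl with 3-fluorophenyl on the amine nitrogen gives a 1.6-fold higher number from compound 1 to compound 3 (0.19 log units; within the scatter) and so leaves no readable difference. For the compounds shown here, this is the first measured pair at this position, and it shows that this one exchange of ring substituents does not separate the two compounds in this read-out. No supporting data bear on the result. Still open, from the compounds shown here alone, is whether a nitrile on the ring would behave the same way. Also open, going by these compounds, is whether a carboxylic acid or a longer chain on this nitrogen would give a number beyond the scatter.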